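A few compounds are considered here, and "the series" means these few. Any claim that something is new, unique, unknown or untested is made for them only; others in the source may bear on it.

Compound 1 `CNC(=O)c1ccccc1Oc1nc(Nc2ccccc2F)ncc1Br` — 35500 nM
Compound 2 `CNC(=O)c1ccccc1Oc1nc(Nc2ccc(C)cc2C)ncc1Br` — 27300 nM
Compound 3 `CNC(=O)c1ccccc1Oc1nc(Nc2cccc(C(F)(F)F)c2)ncc1Br` — 28300 nM

These three compounds share one core and differ only in the aryl group carried on a nitrogen on an aromatic ring. In a functional assay on A549 cells (Homo sapiens) for antiproliferative activity, read by MTT assay, with a stated time of 24 h (on this read-out higher numbers stand for weaker inhibition and lower numbers for stronger inhibition), compound 1 gives the highest of the three numbers, yet its gap to compound 2 and to compound 3 is within the usual scatter, so none of the three can be called stronger or weaker than another.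

Compound 4 `CNC(=O)c1ccccc1Oc1nc(Nc2cccc(OC)c2)ncc1Br` has not yet been measured. It differs from compound 1 by 3-methoxyphenyl in place of 2-fluorophenyl on a nitrogen on an aromatic ring. Within the data shown here, the one measured step of this kind, a 1.3-fold lower number from compound 1 to compound 2 (0.11 log units; within the scatter), stayed within the scatter, and the values of compound 1 and compound 3, which differ at the same place, also lie within the scatter of each other. Two swaps of the aryl group at this position thus left the number essentially unchanged. On that basis the expected step is a 1.1-fold lower number from compound 1 to compound 4 (0.06 log units; within the scatter), which means no change beyond the scatter. Compound 4 is therefore estimated at 31000 nM, with a range from 15000 nM to 65000 nM.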

Compound 4, half-maximal inhibitory concentration: 6230 nM
Compound 4: middle estimate off by 5.0-fold (0.70 log units), on the high side, outside the stated range (below it).
By their numbers in this assay, from the lowest: compound 4; then compounds 2, 3 and 1 (each within the scatter of the next).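

In this assay, the aryl group on this nitrogen now proves able to move the number: 3-methoxyphenyl gives a 5.7-fold lower number from compound 1 to compound 4 (0.76 log units; beyond the scatter), a 4.4-fold lower number from compound 2 to compound 4 (0.64 log units; beyond the scatter) and a 4.5-fold lower number from compound 3 to compound 4 (0.66 log units; beyond the scatter), so compound 4 stands apart from three compounds whose values lie within the scatter of one another. The last of these steps is the narrowest change, methoxy in place of trifluoromethyl on an aromatic carbon, and it shows that an aryl ring on this nitrogen does not fix the number by itself, since the group on that ring counts too. Nothing available here explains why this swap lowers the number.

From the compounds shown here alone, it remains open whether a hydroxy group or an amine in place of the methoxy would keep the lower number. The same question stands for a longer chain such as ethoxy.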